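Amide swap on a nearly inactive antiproliferative compound

The source may hold more compounds than are shown below. What is called first, only, known or untested is meant among the compounds shown, and "the series" means these compounds.

Measured in a functional assay on MCF7 cells (Homo sapiens) for antiproliferative activity, read by CCK-8 assay, with a stated time of 48 h; a lower number here means a stronger inhibitor, a higher number a weaker inhibitor:
- compound 1 `CNC(=O)/C=C/CN1CC(Oc2ccc(Oc3c(-c4ccc(F)cc4)sc4cc(O)ccc34)cc2)C1`: > 25000 nM
- compound 2 `C=CC(=O)NCCOc1ccc(Oc2c(-c3ccc(F)cc3)sc3cc(O)ccc23)cc1`: 23000 nM
- compound 3 `CN(C)C(=O)/C=C/CNCCOc1ccc(Oc2c(-c3ccc(F)cc3)sc3cc(O)ccc23)cc1`: 13800 nM

Compound 1 stands at the limit of > 25000 nM in this assay, at which 1 of the 3 values shown sits, so it offers a limit of the assay and not a number.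

Compound 4 `O=C(/C=C/CN1CC(Oc2ccc(Oc3c(-c4ccc(F)cc4)sc4cc(O)ccc34)cc2)C1)N1CCCC1` differs from compound 1 in one place, with pyrrolidin-1-yl in place of methylamino on a carbonyl carbon. The side chain thus changes from 3-(methylcarbamoyl)prop-2-en-1-yl to 3-((pyrrolidin-1-yl)carbonyl)prop-2-en-1-yl.

Among the compounds with values here, no measured step makes this change alone. Within the data shown here, the steps that bear on it most closely, an at least 1.8-fold lower number from compound 1 to compound 3 (0.25 log units; that floor lies within the scatter) and an at least 1.0-fold lower number from compound 1 to compound 2 (0.03 log units; that floor lies within the scatter), each replace the whole group on the oxygen. A further step, a 1.7-fold lower number from compound 2 to compound 3 (0.22 log units; within the scatter), changes the group on the amine nitrogen. All three stay within the scatter, so no step beyond the scatter is expected in this assay.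

The expected change is a number no higher from compound 1 to compound 4 (the limit leaves the size open), an estimate that carries no firm direction. Compound 4 is estimated at 25000 nM, with an expected range of 12000 nM to 50000 nM.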

Compound 4, half-maximal inhibitory concentration: 8450 nM
Estimate against measurement, compound 4: 3.0-fold (0.47 log units) above, outside the stated range (below it).
By their numbers in this assay, from the lowest: compounds 4, 3 and 2 (each within the scatter of the next, the first and the last beyond it). At a limit, above all of these: compound 1.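

In this assay, within the data shown here, putting pyrrolidin-1-yl in place of methylamino on the carbonyl carbon, which removes the one hydrogen-bond donor of methylamino, gives the first step in this set to clear the usual scatter: an at least 2.9-fold lower number from compound 1 to compound 4 (0.47 log units; beyond the scatter). The earlier steps shown here replaced the whole group on the oxygen or changed the group on the amine nitrogen and stayed within the scatter, whereas this one shows that a change on the carbonyl carbon alone can shift the number while the rest of the molecule stays fixed. Compound 1 is held at a limit, so the step gives only a floor and not a full size: the limit of > 25000 nM in this assay, at which 1 of the 4 values shown sits.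

The compounds shown cannot separate the effect of the ring from the loss of the amide hydrogen, a question that dimethylamino, piperidin-1-yl or morpholin-4-yl on the same carbonyl carbon would bear on. As far as these compounds go, compound 4 gives 8450 nM, and how much lower the number can go through changes at this position stays open.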